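Adding a methyl to a weak cytotoxic indole scaffold

A few compounds are considered here, and "the series" means these few. Any claim that something is new, unique, unknown or untested is made for them only; others in the source may bear on it.

Measured so far:
compound 1 `Cc1[nH]c2ccccc2c1C(c1ccccc1)c1cc2ccccc2o1`: 56500 nM
compound 2 `COc1ccc(C(c2cc3ccccc3o2)c2c[nH]c3ccccc23)cc1`: > 100000 nM

In a functional assay on SiHa cells (Homo sapiens) for cytotoxicity (a lower number here means a stronger inhibitor, a higher number a weaker inhibitor), compound 1 gives 56500 nM. Compound 2 is a different matter, since for it this assay returns only a limit, > 100000 nM, rather than a number. That limit is one of the two values shown here, so compound 2 stands at the edge of what the assay can report (the limit of > 100000 nM in this assay, at which 1 of the 2 values shown sits).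

Compound 3 `COc1ccc(C(c2cc3ccccc3o2)c2c(C)[nH]c3ccccc23)cc1` is not yet measured. It differs from compound 2 by a single change, methyl in place of hydrogen on an aromatic carbon. Compound 1 carries the same methyl and is itself a weak inhibitor, which suggests only a small step. The estimate for compound 3 is a step from compound 2 of an at least 1.4-fold lower number from compound 2 to compound 3 (0.15 log units; that floor lies within the scatter). Compound 3 is therefore expected to fall near 70000 nM, within the range from 25000 nM to 200000 nM, with a fair chance that this assay again reports only a limit.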

Compound 3, half-maximal inhibitory concentration: > 100000 nM
Compound 3: a limit, no number; the forecaster's own chance of this, stated with the estimate: 50%; middle value at least 1.4-fold (0.15 log units) from the limit.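

In this assay compound 3 returns only a limit, > 100000 nM, the same limit as compound 2, so the methyl on the aromatic carbon does not bring this scaffold to a readable number, and the step it makes cannot be read. With that methyl present on both sides, the added methoxy gives an at least 1.7-fold higher number from compound 1 to compound 3 (0.24 log units; that floor lies within the scatter), so the true size of this step may be small or may be larger. The effect of the methyl stays hidden because both compounds without a number sit at the same ceiling: the limit of > 100000 nM in this assay, at which 2 of the 3 values shown sit.

From the compounds shown here alone, whether an amine or a longer chain at the methyl position would give a number in this assay stays open. So does whether a carboxylic acid in place of the methoxy would do so.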